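Notes on the step from compound 2 to compound 3

A few compounds are considered here, and "the series" means these few. Any claim that something is new, unique, unknown or untested is made for them only; others in the source may bear on it.

Compound 1 `CCCCC(CC)N(Cc1ccc(C(=O)NCCC(=O)O)cc1)C(=O)Nc1ccc(OC(F)(F)F)cc1` is measured in an in vitro assay on BHK cells for inhibition of Glucagon receptor (Homo sapiens) (on this read-out higher numbers stand for weaker inhibition and lower numbers for stronger inhibition), at 141 nM. Compound 2 `O=C(O)CCNC(=O)c1ccc(CN(C(=O)Nc2ccc(OC(F)(F)F)cc2)C2CCC(C(=O)NCC3CC3)CC2)cc1` reaches only the assay limit in this assay, with > 10000 nM. For the measured compounds named here, that limit of > 10000 nM in this assay, at which 1 of the 2 values shown sits, is all that compound 2 shows; no step between compound 1 and compound 2 is drawn, since they differ in more than one place. Compound 3 `O=C(O)CCNC(=O)c1ccc(CN(C(=O)Nc2ccc(OC(F)(F)F)cc2)C2CCC(C(=O)O)CC2)cc1` carries hydroxy in place of (cyclopropylmethyl)amino on a carbonyl carbon, hydroxy in place of (cyclopropylmethyl)amino on a carbonyl carbon. Nothing measured anchors the size of this change. For compound 3 the expectation in this assay is 8000 nM, spanning 1500 nM to 30000 nM. The expected step of an at least 1.2-fold lower number from compound 2 to compound 3 (0.09 log units; that floor lies within the scatter) is thus of undetermined direction beyond the scatter.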

Compound 3, half-maximal inhibitory concentration: > 10000 nM
Compound 3 gave a limit, no number; the forecaster's own chance of this, stated with the estimate: 60%; middle value at least 1.2-fold (0.09 log units) away from the limit.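

Putting hydroxy in place of (cyclopropylmethyl)amino on the carbonyl carbon brings no value under the limit: compound 2 and compound 3 both give limits, and the step between them cannot be read. The readings now gather at one limit: the limit of > 10000 nM in this assay, at which 2 of the 3 values shown sit. What is new is a readable step on the amide-type nitrogen, where 4-carboxycyclohexyl in place of 1-ethylpentyl gives an at least 70-fold higher number from compound 1 to compound 3 (1.85 log units; beyond the scatter) in this assay. Open, as far as these compounds go, is whether a plain cyclohexyl on that nitrogen, without the carboxy, gives a value close to that of compound 1 or also reaches the limit.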